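The source may hold more compounds than are shown below. What is called first, only, known or untested is meant among the compounds shown, and "the series" means these compounds.

Compound 1 `N/C(=N\NC(=S)N1CCOCC1)c1ccccn1`: 43.1%
Compound 2 `Cc1ccnc(/C(N)=N/NC(=S)N2CCOCC2)c1`: 35.5%
Compound 3 `Cc1cccc(/C(N)=N/NC(=S)N2CCSCC2)n1`: 51.7%

All three were measured in a functional assay on A-431 cells (Homo sapiens) for cytotoxicity, read by MTT assay, with a stated time of 72 h, tested at 3 uM; a lower number here means less inhibition of growth, a higher number more inhibition of growth at the concentration tested. Compound 1 stands second highest of the three numbers, with compound 2 nearest and compound 3 furthest, both within the usual scatter. Within the data shown here, the only measured single change is a number 7.6 percentage points lower from compound 1 to compound 2 (within the scatter), a methyl swap on the aromatic part that stays within the scatter and says nothing about the ring on the thiocarbonyl carbon. Compound 4 `N/C(=N\NC(=S)N1CCCCC1)c1ccccn1` has not yet been measured; it differs from compound 1 by piperidin-1-yl in place of morpholin-4-yl on a thiocarbonyl carbon. Among the measured compounds shown here, no measured step touches that ring, so nothing here points to a shift beyond the scatter. The step expected is therefore a number 1.9 percentage points higher from compound 1 to compound 4 (within the scatter). Compound 4 is estimated to give 45% in this assay, within a range from 30% to 60%.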

Compound 4, percent growth inhibition at one concentration: 27%
Beside the measured number, compound 4's estimate is 18 percentage points above it, and the stated range ends above it.
By their numbers in this assay, from the lowest: compounds 4, 2, 1 and 3 (each within the scatter of the next, the first and the last beyond it).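

Placing piperidin-1-yl in place of morpholin-4-yl on a thiocarbonyl carbon gives a number 16.1 percentage points lower from compound 1 to compound 4 (beyond the scatter) in this assay, so this position, unlike the methyl change measured earlier, can move the read-out beyond the scatter. The two groups match in heavy-atom count, and morpholin-4-yl holds an oxygen where piperidin-1-yl holds carbon, so a single ring-atom change is enough for this step. Nothing available here explains the step.

Still open, on these data alone, is how piperazin-1-yl or an open-chain dimethylamino group would behave on this thiocarbonyl carbon, with the core of compound 1 unchanged.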